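Swapping a sulfur-bearing chain for hydroxymethyl on an amidine

The compounds below may be only part of what the source reports. "The series", "measured", "known", "first", "only" and "open" are said of these compounds alone.

Measured so far:
compound 1 `N=C(CS)Nc1cccc2c1CCCC2` gives 14%
compound 2 `CC(S)C(=N)NCC(C)(C)C` gives 28%
compound 3 `N=C(CCSSCCC(=N)NCc1ccccc1)NCc1ccccc1` gives 42%

Of the compounds shown here, three have been tested in a functional assay on the whole organism (stomach, strain beagle) for inhibition, with Canis familiaris (Canis lupus familiaris) as the target, with a stated time of 2 h, at a dose of 16 mg/kg; on this read-out lower numbers stand for a weaker effect and higher numbers for a stronger effect at the one dose given. Compound 2 stands second highest of the three numbers. Its nearest neighbour is compound 1, whose value is lower by a gap beyond the usual scatter; the furthest is compound 3, whose value is higher, also beyond the scatter. No pair among these three differs in a single place, so the numbers show only where each compound stands, not what any one change does.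

The unmeasured compound 4 `CC(C)(C)CNC(=N)CO` is compared with compound 2. The difference is hydroxymethyl in place of 1-sulfanylethyl on a carbon with a double bond to nitrogen. Among the compounds with values here, no measured pair shows the effect of removing the sulfur-bearing group, so the size of the step in this assay rests on judgement alone. Every measured compound carries sulfur, and compound 4 does not; on that ground a weaker read-out is expected rather than a stronger one, with a step of moderate size, though a result within the scatter of compound 2 cannot be ruled out.

The expected step from compound 2 to compound 4 is a number 12 percentage points lower from compound 2 to compound 4 (beyond the scatter). Compound 4 is therefore estimated at 16%, with a range from 3% to 32%.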

Compound 4, a percentage reported as inhibition, in the whole organism at one dose (the size of the read-out at that dose, not a potency): 61%
Estimate against measurement, compound 4: 45 percentage points below, and the stated range ends below it.
By their numbers in this assay, from the lowest: compound 1; then compound 2; then compound 3; then compound 4.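

In this assay, hydroxymethyl in place of 1-sulfanylethyl on a carbon with a double bond to nitrogen gives a number 33 percentage points higher from compound 2 to compound 4 (beyond the scatter), the only single change among the compounds shown. It shows that the sulfur-bearing group is not required at this place for a strong read-out at the one dose given, and that taking it out here goes with a gain rather than a loss. Nothing at hand explains the size or the direction of this step.

The compounds shown do not separate the loss of the sulfur-bearing group from the arrival of hydroxymethyl, as the one exchange does both at once, and a plain methyl, an aminomethyl or a longer chain such as 2-hydroxyethyl at this place would be needed to tell these apart. They also leave open whether the same exchange would give a step of this size on the cores of compound 1 or compound 3, and, with a single dose and a single time, whether the step reflects potency at all.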